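The source may hold more compounds than are shown below. What is called first, only, known or untested is meant among the compounds shown, and "the series" means these compounds.

Compound 1 `CC(C)=CCc1cc(C(=O)Nc2cc3ccc(OCCC4CCCCN4)c(C)c3oc2=O)ccc1O` gives 710 nM in a functional assay on MCF7 cells (Homo sapiens) for antiproliferative activity; on this read-out lower numbers stand for stronger inhibition and higher numbers for weaker inhibition.
Compound 2 `CCCNCCCOc1ccc2cc(NC(=O)c3ccc(O)c(CC=C(C)C)c3)c(=O)oc2c1C` gives 980 nM in this assay.

For the measured compounds named here, of these two numbers, the one for compound 2 is the higher, yet its only neighbour, compound 1, sits within the scatter of it: a 1.4-fold higher number from compound 1 to compound 2 (0.14 log units; within the scatter). Compound 3 `CC(C)=CCc1cc(C(=O)Nc2cc3ccc(OCCCNCC(N)=O)c(C)c3oc2=O)ccc1O` differs from compound 2 in the tail of the chain: carbamoyl in place of ethyl on a saturated chain carbon bound to an amine nitrogen. Going by the values given here, the one measured step also changed that tail, by exchanging the group two bonds along the chain from an oxygen on the aromatic ring, and it stayed within the scatter. Among the compounds with values here, no step at the saturated chain carbon bound to the amine nitrogen itself has been measured. Because a 1.4-fold higher number from compound 1 to compound 2 (0.14 log units; within the scatter) was small, the step of a 1.2-fold higher number from compound 2 to compound 3 (0.09 log units; within the scatter) is expected to remain within the scatter as well, with no clear direction. Compound 3 is therefore estimated at 1200 nM, within a range from 450 nM to 3200 nM.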

Compound 3, half-maximal inhibitory concentration: 1460 nM
Estimate against measurement, compound 3: 1.2-fold (0.09 log units) below; measured number inside the range.
By their numbers in this assay, from the lowest: compounds 1, 2 and 3 (each within the scatter of the next, the first and the last beyond it).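

In this assay, carbamoyl in place of ethyl on the saturated chain carbon bound to an amine nitrogen gives a 1.5-fold higher number from compound 2 to compound 3 (0.17 log units; within the scatter) and so leaves the read-out of compound 3 indistinguishable from that of compound 2 at this carbon. Set against the piperidin-2-yl tail, the same ((carbamoylmethyl)amino)methyl tail gives a 2.1-fold higher number from compound 1 to compound 3 (0.31 log units; beyond the scatter) and is the first step here to pass the scatter, though only modestly, even though compound 2 lies within the scatter of both compound 1 and compound 3. No available evidence bears on either step.

On these data alone, whether a carboxylic acid in place of carbamoyl would stay within the scatter of compound 3 remains open. So does the outcome of a morpholine or a butylamino group in place of the tails shown.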